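The compounds below may be only part of what the source reports. "The series", "measured", "known", "first", "only" and "open" are said of these compounds alone.

Compound 1 `Cc1ccnc(/C(N)=N/NC(=S)N2CCSCC2)c1` gives 74.2% in a functional assay on MCF7 cells (Homo sapiens) for cytotoxicity, read by MTT assay, with a stated time of 72 h, tested at 30 uM (a higher number here means more inhibition of growth at the concentration tested, a lower number less inhibition of growth), the highest of the three numbers in hand. Compound 2 `N/C(=N\NC(=S)N1CCSCC1)c1ccccn1` gives 72.6% in this assay; the step of a number 1.6 percentage points lower from compound 1 to compound 2 (within the scatter) is within the scatter, so no order between compound 1 and compound 2 can be read. Compound 3 `Cc1cccc(/C(N)=N/NC(=S)N2CCCCCC2)n1` gives 38.8% in this assay, a number well below that of compound 1 and beyond the scatter; compound 3 differs from compound 1 in more than one place, so this gap is not assigned to any single change.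

Compound 4 `Cc1ccnc(/C(N)=N/NC(=S)N2CCCC2)c1` is not yet measured. Against compound 1 the change is pyrrolidin-1-yl in place of thiomorpholin-4-yl on a thiocarbonyl carbon. Among the measured compounds shown here, none of the measured steps alters the ring on the thiocarbonyl carbon in isolation: the step from compound 1 to compound 2 concerns only the methyl on the aromatic ring, and compound 3 carries both another ring and another methyl position. For the measured compounds named here, the only guide is that compound 3, the one measured compound with another ring at this carbon, shows the lowest number. The expected step is a number 14.2 percentage points lower from compound 1 to compound 4 (beyond the scatter) in this assay, with wide uncertainty. The expected value for compound 4 is 60%, in the range 35% to 80%.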

Compound 4, percent growth inhibition at one concentration: 82.2%
Compound 4: the middle estimate sits 22.2 percentage points below what was measured, and the stated range ends below it.
By their numbers in this assay, from the lowest: compound 3; then compounds 2, 1 and 4 (each within the scatter of the next).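

In this assay, among the compounds shown here, the ring on the thiocarbonyl carbon is changed on its own for the first time, and pyrrolidin-1-yl in place of thiomorpholin-4-yl gives a number 8 percentage points higher from compound 1 to compound 4 (within the scatter). On the core of compound 1, this position therefore accepts a five-membered ring with no sulfur as well as a six-membered ring containing sulfur, with no order to be read between them. Nothing on hand bears on why these two rings give such close numbers.

Still open, on these data alone, is whether an open-chain dimethylamino group or a morpholin-4-yl ring at the same carbon would hold the number on this core. It also remains unresolved whether the ring, the methyl position or both lie behind the value of compound 3, 38.8%.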